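The source may report more compounds than this note shows. Statements on the series, on what has been measured and on what is new or still open speak of the compounds shown alone.

Measured in a functional assay on HCT-116 cells (Homo sapiens) for cytotoxicity, read by MTT assay, with a stated time of 3 days; a higher number here means a weaker inhibitor, a lower number a stronger inhibitor:

Compound 1 `CC(C)N1Cc2ccc(/C=N/Nc3ncnc4sc(C(C)(C)C)cc34)cc2C1` gives 0.206 ug/mL
Compound 2 `CNCc1ccc(/C=N/Nc2ncnc3sc(C(C)(C)C)cc23)cc1` gives 0.056 ug/mL
Compound 3 `CC(C)(C)c1cc2c(N/N=C/c3ccc4c(c3)CNC4)ncnc2s1` gives 0.111 ug/mL

Compound 3 stands second highest of the three numbers, though its distance to each of the other two stays within the scatter. The next case is compound 4 `CN1Cc2ccc(/C=N/Nc3ncnc4sc(C(C)(C)C)cc34)cc2C1`, which has not yet been measured. Its difference from compound 3 is methyl in place of hydrogen on an amine nitrogen in a ring. This is the same nitrogen that carries isopropyl in compound 1.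

Among the measured compounds shown here, the one measured step at that nitrogen is a 1.9-fold lower number from compound 1 to compound 3 (0.27 log units; within the scatter). Even that exchange of isopropyl for hydrogen therefore left the number within the scatter. For the measured compounds named here, compound 2 also carries a methyl, on an amine nitrogen outside any ring, but no single-place step links it to the others, so it serves only as a loose reference. On this evidence, no change beyond the scatter is expected in this assay. The expected step is a 1.2-fold higher number from compound 3 to compound 4 (0.07 log units; within the scatter). Compound 4 is estimated at 0.13 ug/mL, with an expected range from 0.05 ug/mL to 0.32 ug/mL.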

Compound 4, half-maximal inhibitory concentration: 0.088 ug/mL
Estimate against measurement, compound 4: 1.5-fold (0.17 log units) above; measured number inside the range.
By their numbers in this assay, from the lowest: compounds 2, 4, 3 and 1 (each within the scatter of the next, the first and the last beyond it).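

In this assay the amine nitrogen in a ring can now be compared across three substituents, hydrogen, methyl and isopropyl, and the new exchange of hydrogen for methyl stays within the scatter (a 1.3-fold lower number from compound 3 to compound 4 (0.10 log units; within the scatter)). Among the compounds shown here, the step from isopropyl to methyl at the same nitrogen is the first at this position to pass beyond the scatter (a 2.3-fold lower number from compound 1 to compound 4 (0.37 log units; beyond the scatter)), though it is modest, whereas the earlier exchange of isopropyl for hydrogen did not pass it (a 1.9-fold lower number from compound 1 to compound 3 (0.27 log units; within the scatter)). This position therefore carries all three groups with only small shifts in the number, and only methyl and isopropyl separate, a thin distinction that rests on three compounds.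

The compounds shown leave open how an ethyl group, a longer chain, an acetyl group or a carboxylic acid on this nitrogen would read in this assay, and whether the separation of methyl from isopropyl would extend to such groups. Nothing available here accounts for that separation, so its origin remains unknown.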